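This account rests on a few compounds, and the source may have more. Where it says the series, first, only, none or still open, it means among the compounds named here.

In a functional assay on MCF7 cells (Homo sapiens) for cytotoxicity, read by trypan blue exclusion, with a stated time of 48 h (on this read-out lower numbers stand for stronger inhibition and higher numbers for weaker inhibition), compound 2 `Cc1ccc(-c2csc(NC(=O)COc3ccccc3C)n2)cc1` gives 53200 nM. Compound 1 `Cc1ccc(-c2csc(NC(=O)COc3ccc(Cl)c(C)c3)n2)cc1` gives 41500 nM, and compound 3 `Cc1ccc(-c2csc(NC(=O)COc3ccccc3C(C)C)n2)cc1` gives 49000 nM, so compound 2 stands within the scatter of both. The step to compound 4 `Cc1ccc(OCC(=O)Nc2nc(-c3ccc(C)cc3)cs2)cc1` is 4-methylphenyl in place of 2-methylphenyl on an oxygen on a saturated carbon. Among the measured compounds shown here, two measured steps bear on it, both changes on the same side of the shared core: the step of a 1.3-fold higher number from compound 1 to compound 2 (0.11 log units; within the scatter) and the step of a 1.1-fold lower number from compound 2 to compound 3 (0.04 log units; within the scatter). Neither moved the number beyond the scatter, so for the present change a step of no size beyond the scatter is expected in this assay, in either direction. Compound 4 is therefore estimated at 50000 nM, with a range from 25000 nM to 100000 nM, an expected step of a 1.1-fold lower number from compound 2 to compound 4 (0.03 log units; within the scatter).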

Compound 4, half-maximal inhibitory concentration: 41400 nM
Compound 4: the middle estimate sits 1.2-fold (0.08 log units) above what was measured; the range from low to high includes it.
By their numbers in this assay, from the lowest: compounds 4, 1, 3 and 2 (each within the scatter of the next).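

In this assay, 4-methylphenyl in place of 2-methylphenyl, the same atoms joined differently, gives a small step (a 1.3-fold lower number from compound 2 to compound 4 (0.11 log units; within the scatter)), and 4-methylphenyl in place of 4-chloro-3-methylphenyl gives another (a 1.0-fold lower number from compound 1 to compound 4 (0.00 log units; within the scatter)). Both lie within the scatter, so rearranging these atoms on this ring, like the earlier swaps, shows no measurable effect at this place. Nothing available explains this flat result. Going by these compounds, whether an amine or a carboxylic acid on this ring, or a longer chain in place of the methyl, would move the number beyond the scatter remains open.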